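Moving the Ring Oxygen-Bearing Nitrogen: Compound 3 to Compound 4

A few compounds are considered here, and "the series" means these few. Any claim that something is new, unique, unknown or untested is made for them only; others in the source may bear on it.

Of the compounds shown here, three sharing one core have been measured in an assay on CHO cells for displacement of a labelled ligand from Substance-P receptor (Homo sapiens), in the presence of a further agent that is not named here; on this read-out higher numbers stand for weaker inhibition and lower numbers for stronger inhibition. Compound 1 `C[C@@H](O[C@H]1CN2C(=O)C=C(c3ccccc3)CC2[C@@H]1c1ccc(F)cc1)c1cc(C(F)(F)F)cc(C(F)(F)F)c1` gives 89.5 nM. Compound 2 `C[C@@H](O[C@H]1CN2C(=O)C=C(c3ccc(CO)cc3)CC2[C@@H]1c1ccc(F)cc1)c1cc(C(F)(F)F)cc(C(F)(F)F)c1`, which carries hydroxymethyl in place of hydrogen on an aromatic carbon, gives 23 nM. Compound 3 `C[C@@H](O[C@H]1CN2C(=O)C=C(c3cc[n+]([O-])cc3)CC2[C@@H]1c1ccc(F)cc1)c1cc(C(F)(F)F)cc(C(F)(F)F)c1` gives 2.1 nM, the lowest of the three numbers: the step is a 43-fold lower number from compound 1 to compound 3 (1.63 log units; beyond the scatter) and an 11-fold lower number from compound 2 to compound 3 (1.04 log units; beyond the scatter), both well beyond the scatter.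

Compound 4 `C[C@@H](O[C@H]1CN2C(=O)C=C(c3ccc[n+]([O-])c3)CC2[C@@H]1c1ccc(F)cc1)c1cc(C(F)(F)F)cc(C(F)(F)F)c1` is built from the same atoms as compound 3, joined differently. The change is a group of 7 heavy atoms (5 carbon, 1 nitrogen, 1 oxygen; one six-membered aromatic ring with 1 hetero atom) in place of a group of 7 heavy atoms (5 carbon, 1 nitrogen, 1 oxygen; one six-membered aromatic ring with 1 hetero atom), on a double-bonded ring carbon. Going by the values given here, no measured step tests this particular rearrangement; the two steps into compound 3 only show that this ring, in its present arrangement, brings a large improvement over a ring of carbon alone or one bearing hydroxymethyl. Among the compounds with values here, with no direct precedent, a modest loss or a step within the scatter seems most plausible for compound 4, so the expected step is a 2.1-fold higher number from compound 3 to compound 4 (0.33 log units; beyond the scatter). Compound 4 is therefore estimated at 4.5 nM, with a range from 1.5 nM to 14 nM.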

Compound 4, half-maximal inhibitory concentration: 2.3 nM
Estimate against measurement, compound 4: 2.0-fold (0.29 log units) above; measured number inside the range.
By their numbers in this assay, from the lowest: compounds 3 and 4 (each within the scatter of the next); then compound 2; then compound 1.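

In this assay, going by these compounds alone, joining the atoms of this six-membered aromatic ring with 1 hetero atom differently gives a 1.1-fold higher number from compound 3 to compound 4 (0.04 log units; within the scatter), so at this double-bonded ring carbon the improvement is not tied to the single arrangement seen in compound 3. The new arrangement also keeps its clear advantage over the two rings of carbon only, with a 10-fold lower number from compound 2 to compound 4 (1.00 log units; beyond the scatter) and a 39-fold lower number from compound 1 to compound 4 (1.59 log units; beyond the scatter) on the same read-out. No supporting information is available to explain why the two arrangements give such similar numbers.

The compounds shown leave open whether the oxygen on the ring nitrogen matters, which the same ring without that oxygen would test. Also open, as far as these compounds go, is whether an amine or a carboxylic acid on this ring would keep the numbers this low.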